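Changing the Sulfonyl Aryl Group: Expected Effect on Cytotoxicity

The compounds below may be only part of what the source reports. "The series", "measured", "known", "first", "only" and "open" are said of these compounds alone.

Measured so far in an ADME assay on HepG2 2.2.15 cells (Homo sapiens) for cytotoxicity; on this read-out lower numbers stand for higher toxicity in this test and higher numbers for lower toxicity in this test:
- compound 1 `CCCCC(CC)CNc1ncc(C(Oc2ccc3cc(Br)ccc3c2)c2ccc(Cl)cc2)s1`: "not toxic" (no number reported)
- compound 2 `O=C(Nc1ncc(C(Oc2ccc3cc(Br)ccc3c2)c2ccc(Cl)cc2)s1)c1ccc(F)cc1F`: "not toxic" (no number reported)
- compound 3 `O=S(=O)(Nc1ncc(C(Oc2ccc3cc(Br)ccc3c2)c2ccc(Cl)cc2)s1)c1ccc2c(c1)CCO2`: > 50000 nM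

All three share the same core and differ only in the group attached to the ring nitrogen of that core. For compound 1 and compound 2 this assay reports no number, only the statement that each was not toxic. For compound 3 the value is a limit of the assay rather than a measured number: compound 3 sits at the limit of > 50000 nM in this assay, at which 1 of the 3 values shown sits, meaning the assay found no toxicity up to the highest concentration tested. No pair of these compounds gives a measured step, so there is no numerical trend to build on.

Compound 4 `O=S(=O)(Nc1ncc(C(Oc2ccc3cc(Br)ccc3c2)c2ccc(Cl)cc2)s1)c1cccc2nsnc12` keeps the sulfonamide link of compound 3 and changes only the aryl part on the sulfonyl sulfur: a group of 9 heavy atoms (6 carbon, 2 nitrogen, 1 sulfur; one five-membered aromatic ring with 3 hetero atoms, one six-membered aromatic ring of carbon only) in place of a group of 9 heavy atoms (8 carbon, 1 oxygen; one five-membered non-aromatic ring with 1 hetero atom, one six-membered aromatic ring of carbon only), on a sulfonyl sulfur. Since every compound shown so far was either not toxic or at the limit, the expectation for this change in this assay is a step of no size beyond the scatter, in no particular direction. Compound 4 is therefore expected to give 50000 nM, with a range from 20000 nM to 120000 nM. The expected step of a number no higher from compound 3 to compound 4 (the limit leaves the size open) is estimated to be none beyond the scatter, and the most likely outcome is that compound 4 is also reported only as a limit.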

Compound 4, half-maximal cytotoxic concentration: "not toxic" (no number reported)
For compound 4 the study gives words and no number, so the estimate cannot be set against anything.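

No step can be read between compound 3 and compound 4 in this assay; compound 4 is described only in words. Compound 3 gives > 50000 nM, which is a limit of the assay and not a number. The compounds shown leave open whether changing the aryl group on the sulfonyl sulfur affects this read-out at all.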